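The source may hold more compounds than are shown below. What is called first, only, known or untested is meant among the compounds shown, and "the series" means these compounds.

Compound 2, `O=C(Nc1ccc(C(F)(F)F)cc1)c1c[nH]c(Cc2c(Cl)cccc2Cl)n1`: 230 nM
Compound 1, `O=C(Nc1ccccc1Br)c1csc(Cc2c(Cl)cccc2Cl)n1`: > 4000 nM

Going by the values given here, in an assay on CHO cells, read by calcium flux (on this read-out higher numbers stand for weaker inhibition and lower numbers for stronger inhibition), compound 2 gives 230 nM, the only plain number among the values shown. Compound 1 gives > 4000 nM in this assay, which is a limit of the assay rather than a measured number (the limit of > 4000 nM in this assay, at which 1 of the 2 values shown sits). Among the compounds with values here, the two compounds differ in more than one place, so their values show only that compound 2 has a measured number while compound 1 sits at the limit.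

Compound 3 `Cn1cc(C(=O)Nc2ccc(C(F)(F)F)cc2)nc1Cc1c(Cl)cccc1Cl` differs from compound 2 in a single place: methyl in place of hydrogen on an aromatic nitrogen. Within the data shown here, no measured pair shows what methyl in place of hydrogen on an aromatic nitrogen does in this assay. The step expected from compound 2 to compound 3 is therefore modest, a 1.7-fold higher number from compound 2 to compound 3 (0.24 log units; within the scatter), leaning toward slightly weaker inhibition but possibly within the scatter. Compound 3 is estimated to give 400 nM in this assay, within a range from 100 nM to 2000 nM.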

Compound 3, half-maximal inhibitory concentration: 1020 nM
The estimate for compound 3 lay 2.6-fold (0.41 log units) below the measured number; the range from low to high includes it.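

Placing methyl instead of hydrogen on this aromatic nitrogen gives a 4.4-fold higher number from compound 2 to compound 3 (0.65 log units; beyond the scatter) in this assay, the first measured evidence that this position responds to a change and that even a single added carbon can weaken inhibition by more than the usual scatter. This one step cannot separate the loss of the hydrogen from the arrival of the methyl, and no reason for the change can be drawn from it. The weakening also stops short of the assay's limit, since compound 3 has a measured number while compound 1 alone sits at a limit, which is not a number: the limit of > 4000 nM in this assay, at which 1 of the 3 values shown sits.

The compounds shown leave open whether an ethyl group or a longer chain on this nitrogen would weaken inhibition still more. They also leave open how a chain ending in an amine or a carboxylic acid would behave there.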